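The compounds below may be only part of what the source reports. "The series", "measured", "known", "first", "only" and "open" are said of these compounds alone.

Measured compounds in a functional assay on HepG2 cells (Homo sapiens) for antiproliferative activity, read by CCK-8 assay, with a stated time of 72 h, tested at 2 uM; a higher number here means a stronger effect of the compound at the concentration tested, a lower number a weaker effect:
- compound 1 `Nc1ccccc1NC(=O)/C=C/c1ccc(Cn2cnc3c(Nc4cccc(Cl)c4)nc(Cl)nc32)cc1` gives 35.8%
- compound 2 `Nc1ccccc1NC(=O)/C=C/c1ccc(Cn2cnc3c(Nc4ccccc4)nc(Cl)nc32)cc1` gives 16.4%
- compound 3 `Cc1ccc(Nc2nc(Cl)nc3c2ncn3Cc2ccc(/C=C/C(=O)Nc3ccccc3N)cc2)cc1` gives 33.6%

Compound 3 stands second highest of the three numbers in this assay; the steps that lead to it are a number 2.2 percentage points lower from compound 1 to compound 3 (within the scatter) and a number 17.2 percentage points higher from compound 2 to compound 3 (beyond the scatter). Within the data shown here, the one step that is clearly beyond the scatter is a number 19.4 percentage points lower from compound 1 to compound 2 (beyond the scatter).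

Compound 4 `CC1CCN(c2nc(Cl)nc3c2ncn3Cc2ccc(/C=C/C(=O)Nc3ccccc3N)cc2)CC1` differs from compound 3 as follows: 4-methylpiperidin-1-yl in place of (4-methylphenyl)amino on an aromatic carbon. Among the measured compounds shown here, no measured step covers this exchange: the steps seen so far only vary the substituent on the phenyl ring that is now removed altogether, so the size and direction of the step in this assay are uncertain. Compound 4 is therefore estimated at 25% (range 5% to 50%), an expected step of a number 8.6 percentage points lower from compound 3 to compound 4 (within the scatter).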

Compound 4, a percentage reported as inhibition, at one concentration (the size of the read-out at that concentration, not a potency): 8.73%
Compound 4: middle estimate off by 16.3 percentage points, on the high side; measured number inside the range.
By their numbers in this assay, from the lowest: compounds 4 and 2 (each within the scatter of the next); then compounds 3 and 1 (each within the scatter of the next).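

In this assay, this aromatic carbon now carries a non-aromatic ring rather than a varied phenyl ring: 4-methylpiperidin-1-yl gives a number 24.9 percentage points lower from compound 3 to compound 4 (beyond the scatter) and a number 27.1 percentage points lower from compound 1 to compound 4 (beyond the scatter), but only a number 7.7 percentage points lower from compound 2 to compound 4 (within the scatter). The piperidine therefore falls short of the two substituted anilines, while the unsubstituted anilino of compound 2 goes against that pattern. No evidence on hand accounts for these steps.

The change removes both the aromatic ring and the hydrogen-bond donor, and the compounds shown do not separate the two. A cyclohexylamino group or a methyl(phenyl)amino group at this carbon would address that.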